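The source may report more compounds than this note shows. Statements on the series, on what has been measured and on what is new or still open speak of the compounds shown alone.

Measured so far in a functional assay on MCF7 cells (Homo sapiens) for antiproliferative activity, read by MTT assay, with a stated time of 72 h; a higher number here means a weaker inhibitor, a lower number a stronger inhibitor: compound 1 `CCCSc1nc(N/N=C/c2cccnc2)c2nnn(Cc3ccccc3)c2n1` gives 58700 nM; compound 2 `CCCSc1nc(N/N=C(\C)c2ccc(Br)cc2)c2nnn(Cc3ccccc3)c2n1` gives 13000 nM; compound 3 `CCCSc1nc(N/N=C/c2ccccc2)c2nnn(Cc3ccccc3)c2n1` gives > 64000 nM, which is a limit of the assay rather than a number.

Compound 3 thus sits at the floor of this assay (the limit of > 64000 nM in this assay, at which 1 of the 3 values shown sits), the weakest reading shown. Compound 4 `CCCSc1nc(N/N=C/c2ccc(Br)cc2)c2nnn(Cc3ccccc3)c2n1` differs from it by bromo in place of hydrogen on an aromatic carbon. Going by the values given here, the only measured step touching the same ring is an at least 4.9-fold higher number from compound 2 to compound 3 (0.69 log units; beyond the scatter), but compound 2 also carries a methyl on the carbon with the double bond to nitrogen, so that step mixes two changes. The step of an at least 1.0-fold higher number from compound 1 to compound 3 (0.03 log units; that floor lies within the scatter) adds nothing on bromine. A modest gain is expected, an at least 2.2-fold lower number from compound 3 to compound 4 (0.35 log units; beyond the scatter), with compound 4 estimated at 28000 nM, between 11000 nM and 64000 nM.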

Compound 4, half-maximal inhibitory concentration: > 64000 nM
Compound 4: no number, only a limit; the forecaster's own chance of this, stated with the estimate: 30%; at least 2.2-fold (0.35 log units) between middle value and limit.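

Keeping the 4-bromophenyl and removing the methyl on the carbon with a double bond to nitrogen gives an at least 4.9-fold higher number from compound 2 to compound 4 (0.69 log units; beyond the scatter), so bromo alone does not carry the activity of compound 2. Against pyridin-3-yl the reading is an at least 1.0-fold higher number from compound 1 to compound 4 (0.03 log units; that floor lies within the scatter), which sets no order between those two groups. Any effect of bromo on phenyl cannot be read, because compound 3 and compound 4 both stand at a limit and not at a number: the limit of > 64000 nM in this assay, at which 2 of the 4 values shown sit.

From the compounds shown here alone, it remains open whether an amine or a methoxy group in place of bromo would give a readable value. Going by these compounds, it is also open whether an ethyl in place of the methyl would keep the activity of compound 2.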